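Solubility notes on the fused-core series, compounds 1 to 4

The source may report more compounds than this note shows. Statements on the series, on what has been measured and on what is new or still open speak of the compounds shown alone.

compound 1 `Cc1ncccc1-c1cnc(NCc2c(F)ccc3c2CCO3)c2nn(CC#N)c(=O)n12`: 4000 nM
compound 2 `Fc1ccc2c(c1CNc1ncc(Oc3ccccc3)c3nncn13)CCO2`: 8000 nM
compound 3 `CC(=O)N1CCC(c2cnc(NCc3c(F)ccc4c3CCO4)c3cn[nH]c(=O)c23)CC1`: < 2000 nM

Three compounds sharing the fluoro-dihydrobenzofuran-methylamino side chain have been run in a physicochemical assay for solubility, read by LC-MS, in phosphate buffer, with a stated time of 24 h, at pH 7.4; a higher number here means a more soluble compound, a lower number a less soluble compound. In this assay compound 1 gives 4000 nM. In this assay compound 2 gives 8000 nM. For compound 3 this assay returns only a limit, < 2000 nM, not a number. Compound 3 therefore stands at the floor of what has been measured here, (the limit of < 2000 nM in this assay, at which 1 of the 3 values shown sits), and its true value is open below that point. Among the compounds with values here, no two of the measured compounds differ in a single place, so no measured step within the set can be drawn on.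

Compound 4 `CN(c1ccn(C)n1)c1cnc(NCc2c(F)ccc3c2CCO3)c2cn[nH]c(=O)c12` is the next compound, differing from compound 3 in one place: methyl(1-methyl-1H-pyrazol-3-yl)amino in place of 1-acetylpiperidin-4-yl on an aromatic carbon. Since compound 3 holds only a limit, the step in this assay from compound 3 to compound 4 cannot be pinned against a measured baseline; the working expectation is a modest rise, of a size near the edge of the usual scatter, with a real chance that this assay again reports a limit. The estimated step is an at least 1.5-fold higher number from compound 3 to compound 4 (0.17 log units; that floor lies within the scatter). Compound 4 is expected to give about 3000 nM in this assay, within a range of 1000 nM to 9000 nM.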

Compound 4, solubility: 12000 nM
Beside the measured number, compound 4's estimate is 4.0-fold (0.60 log units) below it, and the stated range ends below it.
By their numbers in this assay, from the lowest: compounds 1, 2 and 4 (each within the scatter of the next, the first and the last beyond it). At a limit, below all of these: compound 3.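

In this assay, within the data shown here, methyl(1-methyl-1H-pyrazol-3-yl)amino in place of 1-acetylpiperidin-4-yl on this aromatic carbon of the shared core gives an at least 6.0-fold higher number from compound 3 to compound 4 (0.77 log units; beyond the scatter), the first single-place step in the set and one that lies beyond the usual scatter. Going by these compounds, compound 3 holds only a limit, so this step is a floor and its true size stays open: the limit of < 2000 nM in this assay, at which 1 of the 4 values shown sits. The change also replaces several features at once, with a six-membered non-aromatic ring and its acetyl carbonyl leaving and a five-membered aromatic ring attached through an amino nitrogen entering, so the step belongs to the exchange as a whole and not to any one of these parts.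

Which part of the exchange carries the step remains open, and a plain dimethylamino group or a piperidin-4-yl group without the acetyl on the same aromatic carbon would help to separate the parts. On these data alone, whether a step of this kind would also appear on the cores of compound 1 and compound 2 remains open as well.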